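A Hydroxy-to-Dimethylamino Change on Three Untouched Limits

This account rests on a few compounds, and the source may have more. Where it says the series, first, only, none or still open, it means among the compounds named here.

Of the compounds shown here, three have been tested so far in a functional assay on L1210 cells (Mus musculus) for inhibition; a lower number here means a stronger inhibitor, a higher number a weaker inhibitor. Compound 1, `O=c1[nH]c(=O)n(COCCO)cc1[N+](=O)[O-]`, reaches only the edge of what the assay can report: in this assay compound 1 gives > 1000 ug/mL, which is a limit and not a number. Compound 2, `O=c1[nH]c(=O)n(COCCO)cc1/C=C/Br`, is reported the same way, and in this assay compound 2 gives > 1000 ug/mL, again a limit. For the measured compounds named here, the only measured step, a step that the two limits leave unreadable from compound 1 to compound 2, is therefore unreadable in size. Compound 3, `OCCOCn1cnc2c(O)ncnc21`, is the starting point here, and in this assay compound 3 gives > 1000 ug/mL, also a limit. All three values sit at the limit of > 1000 ug/mL in this assay, at which 3 of the 3 values shown sit.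

Compound 4, `CN(C)c1ncnc2c1ncn2COCCO`, differs from compound 3 in one place: dimethylamino in place of hydroxy on an aromatic carbon. Going by the values given here, no measured step involves hydroxy or dimethylamino, and the single step available carries no readable size, so there is no basis for expecting a shift in this assay beyond the scatter. Compound 4 is expected to give about 1000 ug/mL, between 300 ug/mL and 3000 ug/mL, most probably reported once more as a limit. The expected step of a number no higher from compound 3 to compound 4 (the limit leaves the size open) is estimated as none beyond the scatter.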

Compound 4, concentration for 50% inhibition: > 500 ug/mL
Compound 4: a limit, no number; the forecaster's own chance of this, stated with the estimate: 85%; the middle value lies beyond the limit too.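

In this assay compound 4 gives > 500 ug/mL, which is a limit and not a number. Compound 3 is also reported only as a limit, and the step from compound 3 to compound 4 cannot be read. The compounds shown leave open how strong an inhibitor any of compound 1, compound 2, compound 3 and compound 4 is.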